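Ethoxycarbonyl Gives Way to 4-Chlorophenyl

The source may report more compounds than this note shows. Statements on the series, on what has been measured and on what is new or still open speak of the compounds shown alone.

Compound 1 `C=C[C@@](C)(/C=C/c1ccc(OS(=O)(=O)c2ccc(C)cc2)cc1)CCC=C(C)C` and compound 2 `C=C[C@@](C)(/C=C/c1ccc(O)c(/C=C/C(=O)OCC)c1)CCC=C(C)C` were both tested in a functional assay on HepG2 cells (Homo sapiens) for cytotoxicity, with a stated time of 72 h; a higher number here means that more compound is needed for the effect, a lower number that less compound is needed. Compound 1 gives > 52000 nM, which is a limit and not a number. Compound 2 gives > 52000 nM, which is also a limit. Compound 2 therefore stands at the limit of > 52000 nM in this assay, at which 2 of the 2 values shown sit, and no measured figure fixes its place.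

Compound 3 `C=C[C@@](C)(/C=C/c1ccc(O)c(/C=C/c2ccc(Cl)cc2)c1)CCC=C(C)C` has 4-chlorophenyl in place of ethoxycarbonyl on a double-bonded chain carbon bound to a double-bonded chain carbon. Among the measured compounds shown here, no measured step shows what such a change does in this assay. With compound 2 reading > 52000 nM, a number for compound 3 could only lie on the side of less compound needed, and a modest move that way is expected. The expected change is an at least 2.3-fold lower number from compound 2 to compound 3 (0.37 log units; beyond the scatter). Compound 3 is estimated at 22000 nM, within an expected range of 8000 nM to 52000 nM.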

Compound 3, half-maximal effective concentration: > 52000 nM
Compound 3 was reported as a limit; the forecaster's own chance of this, stated with the estimate: 40%; middle value at least 2.3-fold (0.37 log units) away from the limit.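

In this assay compound 3 gives > 52000 nM, which is a limit and not a number. Among the compounds shown here, compound 2 also stands at a limit, so no step between compound 2 and compound 3 can be read: the limit of > 52000 nM in this assay, at which 3 of the 3 values shown sit. The compounds shown leave open what number, if any, each would reach in this assay.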